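Methoxy to iodo on the aryl triazole of compound 2

The source may hold more compounds than are shown below. What is called first, only, known or untested is meant among the compounds shown, and "the series" means these compounds.

Measured so far in a functional assay on B16 cells (Mus musculus) for cytotoxicity, read by MTT assay, with a stated time of 48 h; on this read-out lower numbers stand for stronger inhibition and higher numbers for weaker inhibition:
- compound 1 `C=C1CC[C@@H](C(C)C)[C@]12CC=C(C=O)CC2` gives 428000 nM
- compound 2 `C=C1CCC[C@]2(C)CCC(c3cn(-c4ccc(OC)cc4)nn3)=CC[C@@]12C` gives 209000 nM

Compound 2 holds the lower of the two numbers; compound 1 stands a step above it that goes beyond the scatter. Among the compounds with values here, compound 3 `C=C1CCC[C@]2(C)CCC(c3cn(-c4ccc(I)cc4)nn3)=CC[C@@]12C` is the one unmeasured member. It differs from compound 2 by iodo in place of methoxy on an aromatic carbon. Within the data shown here, no measured pair shows this change, so its effect is unknown; in this assay the step from compound 2 is expected to stay within the scatter, with no clear direction. Compound 3 is therefore estimated at 150000 nM, between 50000 nM and 450000 nM. The expected step is a 1.4-fold lower number from compound 2 to compound 3 (0.14 log units; within the scatter).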

Compound 3, half-maximal inhibitory concentration: 144000 nM
Compound 3: the middle estimate sits 1.0-fold (0.02 log units) above what was measured; the measured number falls inside the stated range.
By their numbers in this assay, from the lowest: compounds 3 and 2 (each within the scatter of the next); then compound 1.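

In this assay, iodo in place of methoxy on this aromatic carbon gives a 1.5-fold lower number from compound 2 to compound 3 (0.16 log units; within the scatter), so 4-methoxyphenyl and 4-iodophenyl cannot be told apart on this read-out. The position therefore accepts the loss of the methoxy oxygen, with its one hydrogen-bond acceptor, without a step beyond the scatter. No measured evidence bears on this result.

From the compounds shown here alone, whether a different kind of group on this carbon, such as an amine or a carboxylic acid, would move the number beyond the scatter remains open.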